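The source may report more compounds than this note shows. Statements on the series, on what has been measured and on what is new or still open speak of the compounds shown alone.

Working notes on the series. Compound 1 `COc1cc(N(CC2CC2)c2ccc(F)c3ccccc23)cnc1C(=O)[C@H]1C[C@@H]1C(=O)O` gives 0.758 nM in an assay for inhibition of leukotriene C4 synthase (Homo sapiens), read by LC-MS, with stated times of 15 min and 30 min; on this read-out lower numbers stand for stronger inhibition and higher numbers for weaker inhibition. Compound 2 `COc1cc(N(CC(C)C)c2ccc(F)c3ccccc23)cnc1C(=O)[C@H]1C[C@@H]1C(=O)O` gives 0.381 nM in this assay, and compound 3 `CCCN(c1cnc(C(=O)[C@H]2C[C@@H]2C(=O)O)c(OC)c1)c1ccc(F)c2ccccc12` gives 0.626 nM in this assay. Compound 3 holds the second highest of the three numbers; its nearest neighbour is compound 1 and its furthest is compound 2, and both gaps lie within the scatter, so no ordering among the three is claimed.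

Compound 4 `CCN(c1cnc(C(=O)[C@H]2C[C@@H]2C(=O)O)c(OC)c1)c1ccc(F)c2ccccc12` is not yet measured in this assay. From compound 3 to compound 4 the change is hydrogen in place of methyl on a saturated chain carbon, two bonds along the chain from a nitrogen on an aromatic ring. The measured steps that bear on this are the three variations on the same chain: a 1.6-fold higher number from compound 2 to compound 3 (0.22 log units; within the scatter), a 1.2-fold lower number from compound 1 to compound 3 (0.08 log units; within the scatter) and a 2.0-fold lower number from compound 1 to compound 2 (0.30 log units; within the scatter), each within the scatter. Compound 4 is therefore expected to show no step beyond the scatter in this assay, the estimated step being a 1.1-fold higher number from compound 3 to compound 4 (0.05 log units; within the scatter). Compound 4 is estimated at 0.7 nM in this assay, with a range from 0.3 nM to 1.6 nM.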

Compound 4, half-maximal inhibitory concentration: 1.05 nM
For compound 4 the middle estimate is 1.5-fold (0.18 log units) below the measured one, and the stated range covers the measured number.
By their numbers in this assay, from the lowest: compounds 2, 3, 1 and 4 (each within the scatter of the next, the first and the last beyond it).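

The change from propyl to ethyl gives a 1.7-fold higher number from compound 3 to compound 4 (0.22 log units; within the scatter) in this assay and stays as small as the earlier variations on this chain, and methyl in place of cyclopropyl gives a 1.4-fold higher number from compound 1 to compound 4 (0.14 log units; within the scatter) and likewise separates nothing. Methyl in place of isopropyl gives a 2.8-fold higher number from compound 2 to compound 4 (0.44 log units; beyond the scatter) and is the first step in the series beyond the scatter, so compound 2 and compound 4 are the only pair told apart by this chain, while compound 1 and compound 3 fall within the scatter of both. Nothing available accounts for that modest step.

Open, going by these compounds, is whether a longer chain such as butyl, or a chain ending in an amine or a carboxylic acid, would stay within the scatter of compound 4 in this assay or move beyond it. Also open, on these data alone, is whether the step from isopropyl to methyl holds on any other core.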